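A few compounds are considered here, and "the series" means these few. Any claim that something is new, unique, unknown or untested is made for them only; others in the source may bear on it.

In a functional assay on RKO cells (Homo sapiens) for cytotoxicity, read by MTT assay, with a stated time of 48 h (a lower number here means a stronger inhibitor, a higher number a weaker inhibitor), three compounds on a shared core have been measured: compound 1 (`CCCCOc1ccc2c(Cl)ccnc2c1`) gives 3050 nM, compound 2 (`CCCCCCOc1ccc2c(Cl)ccnc2c1`) gives 2720 nM and compound 3 (`Clc1ccnc2cc(OCc3ccccc3)ccc12`) gives 2410 nM. Compound 2 thus stands within the scatter of both others. Compound 4 (`Clc1ccnc2cc(OCCc3ccccc3)ccc12`) differs from compound 2 by phenyl in place of butyl on a saturated chain carbon, two bonds along the chain from an oxygen on an aromatic ring, with phenyl in place of butyl on a saturated chain carbon, two bonds along the chain from an oxygen on an aromatic ring. Going by the values given here, the steps that bear on this are a 1.1-fold lower number from compound 2 to compound 3 (0.05 log units; within the scatter), a 1.3-fold lower number from compound 1 to compound 3 (0.10 log units; within the scatter) and a 1.1-fold lower number from compound 1 to compound 2 (0.05 log units; within the scatter), and all of them lie within the scatter. No change beyond the scatter is therefore expected, and the estimated step is a 1.1-fold lower number from compound 2 to compound 4 (0.05 log units; within the scatter). For compound 4 the expected value is 2400 nM, with an estimated range from 1300 nM to 4300 nM.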

Compound 4, half-maximal inhibitory concentration: 2560 nM
Compound 4: middle estimate off by 1.1-fold (0.03 log units), on the low side, within the range that was stated.
By their numbers in this assay, from the lowest: compounds 3, 4, 2 and 1 (each within the scatter of the next).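

In this assay the step to a phenyl two bonds along the chain from the oxygen gives a 1.1-fold lower number from compound 2 to compound 4 (0.03 log units; within the scatter) and also a 1.2-fold lower number from compound 1 to compound 4 (0.08 log units; within the scatter) and both lie within the scatter. Phenyl had so far stood only on the chain carbon bound to that oxygen, and at this further place, in exchange for butyl or ethyl, it likewise shifts the number by no more than the scatter. No measurement at hand offers an explanation of this result. As far as these compounds go, whether a chain ending in an amine or a carboxylic acid would move the number beyond the scatter stays open.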